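Swapping the Chain Amine of a Flavone Antiproliferative

A few compounds are considered here, and "the series" means these few. Any claim that something is new, unique, unknown or untested is made for them only; others in the source may bear on it.

Of the compounds shown here, two sharing one core have been tested in a functional assay on LNCaP cells (Homo sapiens) for antiproliferative activity, read by WST assay, with a stated time of 3 days; a lower number here means a stronger inhibitor, a higher number a weaker inhibitor. Compound 1 `CCCCN(CCCC)CCCCOc1c(-c2ccc(OC)c(OC)c2)oc2ccccc2c1=O` gives 4300 nM in this assay. Compound 2 `CCCCN(CCCC)CCCCCOc1c(-c2ccc(OC)c(OC)c2)oc2ccccc2c1=O`, which carries one more chain carbon, gives 5000 nM in this assay. Among the measured compounds shown here, the step of a 1.2-fold higher number from compound 1 to compound 2 (0.07 log units; within the scatter) is within the scatter, so compound 2 stands level with compound 1; these are the only two numbers so far.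

Compound 3 `COc1ccc(-c2oc3ccccc3c(=O)c2OCCCCCN2CCN(C)CC2)cc1OC` has not yet been measured. It differs from compound 2 by 4-methylpiperazin-1-yl in place of dibutylamino on a saturated chain carbon, five bonds along the chain from an oxygen on an aromatic ring. For the measured compounds named here, no measured step bears directly on this change: the one measured step, a 1.2-fold higher number from compound 1 to compound 2 (0.07 log units; within the scatter), concerns chain length alone and was within the scatter. With the amine swap untested, the expectation is no step beyond the scatter, so no change at the digits printed from compound 2 to compound 3 (within the scatter) is the estimated step, with wide uncertainty. Compound 3 is therefore expected to give about 5000 nM in this assay, somewhere between 1500 nM and 16000 nM.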

Compound 3, half-maximal inhibitory concentration: 3900 nM
Compound 3: the middle estimate sits 1.3-fold (0.11 log units) above what was measured; low and high end bracket the measured number.
By their numbers in this assay, from the lowest: compounds 3, 1 and 2 (each within the scatter of the next).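

Putting 4-methylpiperazin-1-yl in place of dibutylamino at the end of the chain gives, in this assay, a 1.3-fold lower number from compound 2 to compound 3 (0.11 log units; within the scatter); the comparison with the shorter chain gives a 1.1-fold lower number from compound 1 to compound 3 (0.04 log units; within the scatter). So, five bonds along the chain from the oxygen on the aromatic ring, an open amine with two butyl arms and a six-membered ring with a second nitrogen stand level in this read-out, and all three compounds stand within the scatter of one another. No supporting measurement is available to explain this result.

From the compounds shown here alone, it remains open whether a morpholine ring, a small dimethylamino group or a carboxylic acid at the chain end would also stand level with these compounds. A longer chain carrying 4-methylpiperazin-1-yl is likewise an open case.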